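The source may hold more compounds than are shown below. What is called first, only, known or untested is meant among the compounds shown, and "the series" means these compounds.

Measured compounds:
Compound 1, `CC1(c2ccc(F)cc2)NC(=O)N(CC(O)CN2CCN(c3ccccc3F)CC2)C1=O`: 234 nM
Compound 2, `CC1(c2ccc(F)cc2)NC(=O)N(CC(O)CN2CCN(c3ccc(F)cc3)CC2)C1=O`: 837 nM

In an assay on HEK293 cells for displacement of a labelled ligand from 5-hydroxytryptamine receptor 7 (Homo sapiens) (a lower number here means a stronger inhibitor, a higher number a weaker inhibitor), compound 1 gives 234 nM and compound 2 gives 837 nM. Compound 2 therefore has the higher of the two numbers; the single step shown, a 3.6-fold higher number from compound 1 to compound 2 (0.55 log units; beyond the scatter), separates it from compound 1.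

Compound 3, `CC1(c2ccc(F)cc2)NC(=O)N(CC(O)CN2CCN(c3ccc(Cl)cc3)CC2)C1=O`, is the next variation. Its difference from compound 2 is chloro in place of fluoro on an aromatic carbon, the chloro sitting on an aromatic carbon of a six-membered aromatic ring of carbon only, para to a large group. Within the data shown here, no measured step exchanges one halogen for another on this ring: the only step in hand, a 3.6-fold higher number from compound 1 to compound 2 (0.55 log units; beyond the scatter), moves a fluoro from one carbon of the ring to another and does not speak to chloro in place of fluoro. With nothing to anchor a direction, the step in this assay is expected to stay within the scatter, and the estimate for compound 3 is a 1.2-fold lower number from compound 2 to compound 3 (0.08 log units; within the scatter). Compound 3 is accordingly expected to give about 700 nM, with a range from 250 nM to 2000 nM.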

Compound 3, inhibition constant: 908 nM
The estimate for compound 3 lay 1.3-fold (0.11 log units) below the measured number; low and high end bracket the measured number.
By their numbers in this assay, from the lowest: compound 1; then compounds 2 and 3 (each within the scatter of the next).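

In this assay, among these compounds, chloro in place of fluoro on an aromatic carbon, para to a large group, is the first exchange of one halogen for another on this ring, and a 1.1-fold higher number from compound 2 to compound 3 (0.04 log units; within the scatter) shows that the two halogens cannot be told apart at this place. The gap from the 2-fluorophenyl group also persists with the new halogen: a 3.9-fold higher number from compound 1 to compound 3 (0.59 log units; beyond the scatter) lies beyond the scatter, as does a 3.6-fold higher number from compound 1 to compound 2 (0.55 log units; beyond the scatter), so both the 4-fluorophenyl and the 4-chlorophenyl group carry a higher number than the 2-fluorophenyl group in these pairs. No measurement at hand explains either the match between the two halogens or the gap to the 2-fluorophenyl group.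

The compounds shown leave open whether a group other than a halogen, such as methoxy, methyl or trifluoromethyl, would stay level with fluoro and chloro on this aromatic carbon. They also leave open whether chloro on the ring carbon that bears the fluoro in compound 1 would match that fluoro, as it matches the fluoro of compound 2.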